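Nitro in place of phenyl at the assay limit

The source may hold more compounds than are shown below. What is called first, only, known or untested is meant among the compounds shown, and "the series" means these compounds.

Of the compounds shown here, three have been read in a functional assay on HCT-116 cells (Homo sapiens) for cytotoxicity, read by sulforhodamine B assay, with a stated time of 48 h; a lower number here means a stronger inhibitor, a higher number a weaker inhibitor. Compound 1 `COc1ccc(C(=O)Nc2n[nH]c3c2CN(C(=O)c2ccccc2)C3)cc1` gives 13600 nM, and compound 2 `O=C(Nc1nn(C(=O)c2ccccc2)c2c1CN(C(=O)c1ccccc1)C2)c1ccc(F)cc1` gives 2780 nM. Compound 3 `CC(=O)n1nc(NC(=O)c2ccccc2)c2c1CN(C(=O)c1ccc(-c3ccccc3)cc1)C2` gives > 90000 nM, which is a limit of the assay and not a number. Compound 3 thus stands at the limit of > 90000 nM in this assay, at which 1 of the 3 values shown sits.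

Compound 4 `CC(=O)n1nc(NC(=O)c2ccccc2)c2c1CN(C(=O)c1ccc([N+](=O)[O-])cc1)C2` differs from compound 3 in one place, on an aromatic carbon, para to a large group: nitro in place of phenyl on an aromatic carbon. Among the compounds with values here, no two measured compounds differ in one place only, so this change has no direct precedent in this assay. A moderate move towards a lower number, meaning a stronger inhibitor, is expected, though compound 4 may also stay at the limit. This expectation rests on compound 1 at 13600 nM and compound 2 at 2780 nM, which show that measurable numbers occur in the series. The expected change is an at least 2.5-fold lower number from compound 3 to compound 4 (0.41 log units; beyond the scatter). For compound 4 the estimated value is 35000 nM, with an expected range of 8000 nM to 90000 nM.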

Compound 4, half-maximal inhibitory concentration: 16200 nM
Compound 4: middle estimate off by 2.2-fold (0.33 log units), on the high side; measured number inside the range.
By their numbers in this assay, from the lowest: compound 2; then compounds 1 and 4 (each within the scatter of the next). At a limit, above all of these: compound 3.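

In this assay, the aromatic carbon para to a large group proves responsive to substitution: nitro in place of phenyl gives an at least 5.5-fold lower number from compound 3 to compound 4 (0.74 log units; beyond the scatter). Within the data shown here, the true size of this step remains unknown because compound 3 has a limit of the assay and not a number: the limit of > 90000 nM in this assay, at which 1 of the 4 values shown sits. As the only one-place step, it shows that a change at this position alone can take a compound from the limit to a measurable number.

Going by these compounds, with only phenyl and nitro seen at this position, it remains open whether an amine or a carboxylic acid there would give a lower or a higher number. On these data alone, compounds 1 and 2 differ from compound 4 in more than one place, so whether the step carries over to other parts of the series also remains open.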